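A few compounds are considered here, and "the series" means these few. Any claim that something is new, unique, unknown or untested is made for them only; others in the source may bear on it.

The measured compounds, with their values in the assay:

Compound 1 `O=C1C(Nc2ccccc2)=CC(=O)c2c1nc1n2[C@H]2OC[C@@H](O)[C@H]2OC1`: > 4000 nM
Compound 2 `CCc1ccc(NC2=CC(=O)c3nc4n(c3C2=O)[C@H]2OC[C@@H](O)[C@H]2OC4)cc1`: 960 nM
Compound 3 `O=C1C=C(NC2CCCC2)C(=O)c2c1nc1n2[C@H]2OC[C@@H](O)[C@H]2OC1`: > 16000 nM

In a functional assay on MCF7 cells (Homo sapiens) for inhibition, read by sulforhodamine B assay (a higher number here means a weaker inhibitor, a lower number a stronger inhibitor), compound 2 gives 960 nM. For compound 1 the assay reports only a limit, > 4000 nM, so compound 1 sits at the limit of > 4000 nM in this assay, at which 1 of the 3 values shown sits, and no number is known for it. For compound 3 the result is likewise a limit, > 16000 nM.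

Compound 4 `O=C1C(N2CCC2)=CC(=O)c2c1nc1n2[C@H]2OC[C@@H](O)[C@H]2OC1` differs from compound 1 in one place: azetidin-1-yl in place of anilino on a double-bonded ring carbon. Going by the values given here, the one measured step that bears on this, a saturated ring replacing an aromatic one on the amine nitrogen, was large: an at least 16-fold higher number from compound 2 to compound 3 (1.22 log units; beyond the scatter). A weakening of similar direction is therefore expected here, most likely again ending at a limit. Compound 4 is estimated at 20000 nM, between 5000 nM and 100000 nM, an expected step that the limit leaves unreadable from compound 1 to compound 4.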

Compound 4, half-maximal inhibitory concentration: > 16000 nM
Compound 4 ended at the assay's limit (the forecaster's own chance of this, stated with the estimate: 85%); the middle value lies beyond the limit too.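

Going by these compounds alone, compound 1 and compound 4 both give only limits of the assay, not numbers, so no step between them can be read. Going by these compounds, how far anilino and azetidin-1-yl truly differ on the shared core stays open.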